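Thiophene-fused styryl series: amine replacement on the shared core

A few compounds are considered here, and "the series" means these few. Any claim that something is new, unique, unknown or untested is made for them only; others in the source may bear on it.

Measured compounds:
Compound 1, `CNc1nc(/C=C/c2cc(OC)c(OC)c(OC)c2)nc2ccsc12` — in a functional assay on L02 cells (Homo sapiens) for inhibition, read by Griess assay, with stated times of 1 h and 24 h (on this read-out lower numbers stand for stronger inhibition and higher numbers for weaker inhibition), compound 1 gives > 1000000 nM, which is a limit of the assay.
Compound 2, `CCN1CCN(c2nc(/C=C/c3cc(OC)c(OC)c(OC)c3)nc3ccsc23)CC1` — in this assay compound 2 gives > 1000000 nM, again only a limit.

Going by the values given here, compound 2 therefore has no number of its own: it sits at the limit described by the limit of > 1000000 nM in this assay, at which 2 of the 2 values shown sit, as does every value so far recorded. Among the compounds with values here, the one measured step, a step that the two limits leave unreadable from compound 1 to compound 2, is left unreadable by the two limits, so nothing can be said about its size or direction.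

The next compound, compound 3, `COc1cc(/C=C/c2nc(Nc3ccc(C(F)(F)F)cc3)c3sccc3n2)cc(OC)c1OC`, differs from compound 2 by (4-(trifluoromethyl)phenyl)amino in place of 4-ethylpiperazin-1-yl on an aromatic carbon. Within the data shown here, no measured step bears on this change: the only step on record is unreadable, and no compound with an arylamino group at that carbon has a value. The expectation rests solely on the two limits. Compound 3 is therefore estimated at 500000 nM, with a range from 20000 nM to 5000000 nM, most probably again reported only as a limit. The step this estimate implies, an at least 2.0-fold lower number from compound 2 to compound 3 (0.30 log units; that floor lies within the scatter), is expected to fall within the scatter, given that compound 2 stands at > 1000000 nM.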

Compound 3, half-maximal inhibitory concentration: 436000 nM
The estimate for compound 3 lay 1.1-fold (0.06 log units) above the measured number, within the range that was stated.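

In this assay, (4-(trifluoromethyl)phenyl)amino on this aromatic carbon of the shared core gives the series its first readable number, and so its first steps with a direction. Replacing 4-ethylpiperazin-1-yl gives an at least 2.2-fold lower number from compound 2 to compound 3 (0.36 log units; beyond the scatter), and replacing the methyl on the nitrogen of the methylamino group with 4-(trifluoromethyl)phenyl points the same way, with an at least 2.2-fold lower number from compound 1 to compound 3 (0.36 log units; beyond the scatter). Both steps give only a minimum size and not a true one, since each starts from a compound reported only as a limit: the limit of > 1000000 nM in this assay, at which 2 of the 3 values shown sit.

With a single arylamino compound on record, the change cannot be divided between the phenyl ring and the trifluoromethyl group, and phenylamino, (4-methoxyphenyl)amino or benzylamino at the same carbon would be needed to separate them. It also remains open whether the effect of this change carries over when the 3,4,5-trimethoxyphenyl group at the far end of the styryl arm gives way to another group, such as a plain phenyl ring, since that part is the same in all the compounds shown.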